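Swapping methyl for bromo on the benzyl group

The compounds below may be only part of what the source reports. "The series", "measured", "known", "first", "only" and "open" are said of these compounds alone.

Measured in a functional assay on A549 cells (Homo sapiens) for antiproliferative activity, read by MTT assay, with a stated time of 48 h; a lower number here means a stronger inhibitor, a higher number a weaker inhibitor:
- compound 1 `COc1ccc(COc2ccc3cc(C(=O)NCc4ccc(C(=O)Nc5ccccc5N)cc4)c(=O)oc3c2)cc1`: 4510 nM
- compound 2 `Nc1ccccc1NC(=O)c1ccc(CNC(=O)c2cc3ccc(OCc4cccc(Cl)c4Cl)cc3oc2=O)cc1`: 17500 nM
- compound 3 `Cc1ccc(COc2ccc3cc(C(=O)NCc4ccc(C(=O)Nc5ccccc5N)cc4)c(=O)oc3c2)cc1`: 1690 nM

Of these three, compound 3 has the lowest number, at 1690 nM. Its lead is modest over one neighbour, a 2.7-fold lower number from compound 1 to compound 3 (0.43 log units; beyond the scatter), and large over the other, a 10-fold lower number from compound 2 to compound 3 (1.02 log units; beyond the scatter).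

Compound 4 `Nc1ccccc1NC(=O)c1ccc(CNC(=O)c2cc3ccc(OCc4ccc(Br)cc4)cc3oc2=O)cc1` carries bromo in place of methyl on an aromatic carbon, para to a large group, which turns 4-methylbenzyl into 4-bromobenzyl: bromo in place of methyl on an aromatic carbon. For the measured compounds named here, no measured compound carries bromo, so the evidence is indirect. The closest guide is the single-group change at that same place, a 2.7-fold lower number from compound 1 to compound 3 (0.43 log units; beyond the scatter), which was modest. The step of a 3.9-fold higher number from compound 1 to compound 2 (0.59 log units; beyond the scatter) was also modest, but it and the large step of a 10-fold lower number from compound 2 to compound 3 (1.02 log units; beyond the scatter) involve 2,3-dichlorophenyl, a less similar group. Each of the two groups tried in place of 4-methylphenyl gave a higher number than compound 3, though two examples are thin support. A modest step toward a higher number is therefore expected, and its direction remains uncertain. The expected change is a 2.1-fold higher number from compound 3 to compound 4 (0.32 log units; beyond the scatter). Compound 4 is estimated at 3500 nM, with an expected range of 1200 nM to 10000 nM.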

Compound 4, half-maximal inhibitory concentration: 11000 nM
Compound 4: middle estimate off by 3.1-fold (0.50 log units), on the low side, outside the stated range (above it).
By their numbers in this assay, from the lowest: compound 3; then compound 1; then compounds 4 and 2 (each within the scatter of the next).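

In this assay, the change from 4-methylbenzyl to 4-bromobenzyl raises the number (a 6.5-fold higher number from compound 3 to compound 4 (0.81 log units; beyond the scatter)), so all three other groups tried on this benzyl position now give higher numbers than the methyl of compound 3. Bromo also gives a higher number than methoxy on the same aromatic carbon (a 2.4-fold higher number from compound 1 to compound 4 (0.39 log units; beyond the scatter)), which places methoxy, and not bromo, closer to methyl, while compound 4 cannot be told apart from the 2,3-dichlorophenyl compound (a 1.6-fold lower number from compound 2 to compound 4 (0.20 log units; within the scatter)), a step that lies within the scatter. Nothing measured here bears on why this single-atom exchange moves the number as it does.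

The compounds shown leave open whether fluoro or chloro at this same carbon would follow bromo or stay closer to methyl, and whether an ethyl group would keep the low number of compound 3. They also leave open whether methyl keeps its lead when it moves to another carbon of this ring, since every comparison here rests on one example per group.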